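Swapping tert-butyl for piperidin-1-yl on the shared core

This account rests on a few compounds, and the source may have more. Where it says the series, first, only, none or still open, it means among the compounds named here.

Three compounds built on the core of compound 1 `O=C(O)c1cccc(Cc2c(-c3cccs3)nn3cc(Cl)ccc23)n1` have been measured in a functional assay on cells for antagonist activity at prostaglandin E2 receptor EP1 subtype (Rattus norvegicus), read by fluorescence and calcium flux, with a stated time of 60 s; on this read-out lower numbers stand for stronger inhibition and higher numbers for weaker inhibition. Compound 1 gives 1100 nM. Compound 2 `O=C(O)c1cccc(Cc2c(-c3ccsc3)nn3cc(Cl)ccc23)n1` gives 110 nM in this assay; the step of a 10-fold lower number from compound 1 to compound 2 (1.00 log units; beyond the scatter) lies beyond the scatter. Compound 3 `CC(C)(C)c1nn2cc(Cl)ccc2c1Cc1cccc(C(=O)O)n1` gives 48 nM in this assay, the lowest of the three numbers, and the steps of a 23-fold lower number from compound 1 to compound 3 (1.36 log units; beyond the scatter) and a 2.3-fold lower number from compound 2 to compound 3 (0.36 log units; beyond the scatter) set it apart from both others. Compound 4 `O=C(O)c1cccc(Cc2c(N3CCCCC3)nn3cc(Cl)ccc23)n1` carries piperidin-1-yl in place of tert-butyl on an aromatic carbon. Among the measured compounds shown here, no measured step exchanges one non-aromatic group for another; both known steps onto tert-butyl came down from aromatic groups. A modest upward step a 2.1-fold higher number from compound 3 to compound 4 (0.32 log units; beyond the scatter) is therefore expected in this assay. Compound 4 is estimated at 100 nM, with a range from 30 nM to 400 nM.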

Compound 4, half-maximal inhibitory concentration: 79 nM
The estimate for compound 4 lay 1.3-fold (0.10 log units) above the measured number; the range from low to high includes it.
By their numbers in this assay, from the lowest: compounds 3, 4 and 2 (each within the scatter of the next, the first and the last beyond it); then compound 1.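

The piperidin-1-yl group brings the first ring nitrogen to this position, and in this assay it matches the tert-butyl group, with a 1.6-fold higher number from compound 3 to compound 4 (0.22 log units; within the scatter) as the step. Its exchange for thiophen-3-yl is also no clear change, with a 1.4-fold lower number from compound 2 to compound 4 (0.14 log units; within the scatter) as the step. Only thiophen-2-yl stands apart, as a 14-fold lower number from compound 1 to compound 4 (1.14 log units; beyond the scatter) shows alongside its steps to compound 2 and compound 3. From the compounds shown here alone, whether a cyclohexyl or morpholin-4-yl group would fall level with compound 3 and compound 4 stays open. The compounds shown come with no measurement that accounts for these steps.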